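The source may hold more compounds than are shown below. What is called first, only, known or untested is meant among the compounds shown, and "the series" means these compounds.

Compound 3 `COc1ccc(COc2ccc3c(c2)OCC3CC(=O)O)cc1-n1c(C)ccc1C` shares its core with compound 1 `Cc1ccc(C)n1-c1cccc(COc2ccc3c(c2)OCC3CC(=O)O)c1` and compound 2 `COCc1cc(C)n(-c2cccc(COc3ccc4c(c3)OCC4CC(=O)O)c2)c1C`. In a functional assay on CHO cells for agonist activity at Free fatty acid receptor 1 (Homo sapiens), read by FLIPR and calcium flux, with a stated time of 90 s (a higher number here means that more compound is needed for the effect, a lower number that less compound is needed), compound 1 gives 46.9 nM, and compound 3 gives 34.7 nM. For compound 2 the entry in this assay reads "not determined" (no result reported). Compound 3 thus carries the lowest of the two numbers, with compound 1 the nearest, and the step of a 1.4-fold lower number from compound 1 to compound 3 (0.13 log units; within the scatter) lies within the scatter. Compound 4 `CCOc1ccc(COc2ccc3c(c2)OCC3CC(=O)O)cc1-n1c(C)ccc1C` differs from compound 3 by methyl in place of hydrogen on a saturated chain carbon bound to an oxygen on an aromatic ring. Among the measured compounds shown here, the only step that bears on it is a 1.4-fold lower number from compound 1 to compound 3 (0.13 log units; within the scatter), which added a group at the same oxygen and moved the number little. A further extension is therefore expected to give about a 1.0-fold higher number from compound 3 to compound 4 (0.00 log units; within the scatter), no change beyond the scatter. Compound 4 is estimated at 35 nM, within 15 nM to 85 nM.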

Compound 4, half-maximal effective concentration: 61.2 nM
Beside the measured number, compound 4's estimate is 1.7-fold (0.24 log units) below it; the range from low to high includes it.
By their numbers in this assay, from the lowest: compounds 3, 1 and 4 (each within the scatter of the next).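

In this assay, going from methoxy to ethoxy adds one methyl at this position and leaves the number within the scatter (a 1.8-fold higher number from compound 3 to compound 4 (0.25 log units; within the scatter)). Ethoxy in place of hydrogen on the aromatic carbon also stays within the scatter (a 1.3-fold higher number from compound 1 to compound 4 (0.12 log units; within the scatter)), so neither group separates from hydrogen here. No evidence is available to explain these results. The compounds shown leave open whether a longer chain, such as propoxy, would also stay within the scatter. They also leave open how an amine at this position would read.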